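This account rests on a few compounds, and the source may have more. Where it says the series, first, only, none or still open, it means among the compounds named here.

Measured so far: compound 1 `CN1CCN(c2ccc(NC(=O)c3cc4cc(NC(=O)N(C)C)ccc4n3Cc3ccc(C(F)(F)F)cc3)cc2)CC1` gives 1240 nM; compound 2 `CN1CCN(c2ccc(NC(=O)c3cc4cc(NS(C)(=O)=O)ccc4n3Cc3ccc(C(F)(F)F)cc3)cc2)CC1` gives 4910 nM; compound 3 `CCC(=O)Nc1ccc2c(c1)cc(C(=O)Nc1ccc(N3CCN(C)CC3)cc1)n2Cc1ccc(C(F)(F)F)cc1` gives 3330 nM.

All three were measured in a functional assay on RAW264.7 cells (Mus musculus) for inhibition, read by ELISA, with stated times of 30 min and 24 h; a higher number here means a weaker inhibitor, a lower number a stronger inhibitor. Compound 3 stands second highest of the three numbers: its nearest neighbour is compound 2, with a 1.5-fold lower number from compound 2 to compound 3 (0.17 log units; within the scatter), and its furthest is compound 1, with a 2.7-fold higher number from compound 1 to compound 3 (0.43 log units; beyond the scatter). Compound 4 `CN1CCN(c2ccc(NC(=O)c3cc4cc([N+](=O)[O-])ccc4n3Cc3ccc(C(F)(F)F)cc3)cc2)CC1` differs from compound 3 in one place: nitro in place of propanoylamino on an aromatic carbon. Going by the values given here, no measured step introduces a nitro group, so the steps that bear on this change are only those that altered the same position, namely a 4.0-fold higher number from compound 1 to compound 2 (0.60 log units; beyond the scatter), a 2.7-fold higher number from compound 1 to compound 3 (0.43 log units; beyond the scatter) and a 1.5-fold lower number from compound 2 to compound 3 (0.17 log units; within the scatter), all modest or within the scatter. A step of similar modest size in either direction seems most plausible. Compound 4 is therefore expected to show a 1.1-fold higher number from compound 3 to compound 4 (0.02 log units; within the scatter), with an estimate of 3500 nM and a range from 900 nM to 13000 nM.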

Compound 4, half-maximal inhibitory concentration: 5090 nM
The estimate for compound 4 lay 1.5-fold (0.16 log units) below the measured number; low and high end bracket the measured number.
By their numbers in this assay, from the lowest: compound 1; then compounds 3, 2 and 4 (each within the scatter of the next).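

Removing the hydrogen-bond donor of propanoylamino by moving to nitro gives a 1.5-fold higher number from compound 3 to compound 4 (0.18 log units; within the scatter) and so does not separate the two groups at this aromatic carbon. Nitro and methanesulfonamido are likewise not separated, with a 1.0-fold higher number from compound 2 to compound 4 (0.02 log units; within the scatter) in this comparison, so a group with no donor can sit level with both. Only the (dimethylcarbamoyl)amino group stands apart, with a 4.1-fold higher number from compound 1 to compound 4 (0.61 log units; beyond the scatter) in the same direction, and no measurement here explains that gap. Going by these compounds, whether a plain amine or a carboxylic acid here would match compound 1 or the other three stays open.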